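Moving the Halogen Around the Benzyl Ring

The source may hold more compounds than are shown below. What is called first, only, known or untested is meant among the compounds shown, and "the series" means these compounds.

Compound 1 `COc1cc(-c2nnc(SCc3cccc(Br)c3)o2)ccc1O` carries a 3-bromophenyl on the saturated chain carbon bound to a sulfur. In a functional assay on cells (T-cell, Mus musculus, strain BALB/c) for inhibition, read by MTT assay, with stated times of 24 h and 72 h (a higher number here means a weaker inhibitor, a lower number a stronger inhibitor), compound 1 gives 48100 nM, the highest number of the three measured, so it is the weakest inhibitor among them. Compound 2 `COc1cc(-c2nnc(SCc3ccccc3F)o2)ccc1O` gives 5790 nM in this assay, and compound 3 `COc1cc(-c2nnc(SCc3ccccc3Br)o2)ccc1O` gives 17800 nM. Compound 4 `COc1cc(-c2nnc(SCc3ccccc3Cl)o2)ccc1O` has not yet been measured; it differs from compound 1 in this way: 2-chlorophenyl in place of 3-bromophenyl on a saturated chain carbon bound to a sulfur. Within the data shown here, two measured steps bear on this change. an 8.3-fold lower number from compound 1 to compound 2 (0.92 log units; beyond the scatter) and a 2.7-fold lower number from compound 1 to compound 3 (0.43 log units; beyond the scatter) both lowered the number, the 2-fluorophenyl more than the 2-bromophenyl, and a 3.1-fold higher number from compound 2 to compound 3 (0.49 log units; beyond the scatter) shows the gap between those two. Chlorine sits between fluorine and bromine in the halogen series, so the 2-chlorophenyl of compound 4 is expected to fall between compound 2 and compound 3, with a modest lowering from compound 1. The expected size of that step is a 4.8-fold lower number from compound 1 to compound 4 (0.68 log units; beyond the scatter). Compound 4 is therefore estimated at 10000 nM, within a range of 4000 nM to 25000 nM.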

Compound 4, half-maximal inhibitory concentration: 8430 nM
Beside the measured number, compound 4's estimate is 1.2-fold (0.07 log units) above it; the measured number falls inside the stated range.
By their numbers in this assay, from the lowest: compounds 2 and 4 (each within the scatter of the next); then compound 3; then compound 1.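

The 2-chlorophenyl keeps the lower number seen with the other 2-halophenyl groups (a 5.7-fold lower number from compound 1 to compound 4 (0.76 log units; beyond the scatter)), so all three compounds with a halogen at that ring position read lower than compound 1 in this assay. The new compound also separates the two smaller halogens from bromo: swapping bromo for chloro gives a real change (a 2.1-fold lower number from compound 3 to compound 4 (0.32 log units; beyond the scatter)), whereas swapping fluoro for chloro does not (a 1.5-fold higher number from compound 2 to compound 4 (0.16 log units; within the scatter)), leaving compound 2 and compound 4 indistinguishable here. Nothing measured here explains these differences.

Every step away from compound 1 changes both the halogen and its ring position, so the contribution of each remains unresolved. A 3-chlorophenyl or 3-fluorophenyl group would help separate them, while a plain phenyl or a 2-methoxyphenyl group would test whether a halogen is needed at all.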